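Swapping ethoxy for fluoro: what half-life to expect

The source may report more compounds than this note shows. Statements on the series, on what has been measured and on what is new or still open speak of the compounds shown alone.

Compound 1 `CCc1nc(NC(CC)CC)c(Cl)nc1-c1ccc(Cl)cc1Cl`: < 0.0167 h (a limit)
Compound 2 `CCOc1nc(-c2ccc(Cl)cc2Cl)c(CC)nc1NC(CC)CC`: 1.23 h

Among the compounds with values here, in an in vitro ADME assay on microsomes (Rattus norvegicus) for metabolic stability (on this read-out higher numbers stand for a longer-lived compound and lower numbers for a shorter-lived compound), compound 2 gives 1.23 h, the only actual number so far. Compound 1 sits at the limit of < 0.0167 h in this assay, at which 1 of the 2 values shown sits.

Compound 3 `CCc1nc(NC(CC)CC)c(F)nc1-c1ccc(Cl)cc1Cl` carries fluoro in place of ethoxy on an aromatic carbon. Within the data shown here, one measured step bears on this: an at least 73-fold higher number from compound 1 to compound 2 (1.86 log units; beyond the scatter), with ethoxy in place of chloro at that same place. Compound 3 again has a halogen there, though fluoro rather than chloro, so a large drop in this assay is expected, a 21-fold lower number from compound 2 to compound 3 (1.31 log units; beyond the scatter). For compound 3 the estimated half-life is 0.06 h, within a range of 0.0167 h to 0.3 h.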

Compound 3, half-life: 0.35 h
Compound 3: the middle estimate sits 5.8-fold (0.77 log units) below what was measured, outside the stated range (above it).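

Fluoro in place of chloro gives an at least 20-fold higher number from compound 1 to compound 3 (1.32 log units; beyond the scatter) in this assay and so the two halogens do not behave alike at this position. Ethoxy still leads fluoro, with a 3.5-fold lower number from compound 2 to compound 3 (0.55 log units; beyond the scatter) as the step, so a large gain over chloro does not depend on ethoxy alone. Compound 1 stands at a limit and not at a number, so the first step has no known upper end: the limit of < 0.0167 h in this assay, at which 1 of the 3 values shown sits.

On these data alone, whether a methoxy group, a longer alkoxy chain or an amine at this position would match or pass ethoxy stays open.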